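This account rests on a few compounds, and the source may have more. Where it says the series, first, only, none or still open, it means among the compounds named here.

Two compounds from this series come with a record in a functional assay on MDA-MB-231 cells (Homo sapiens) for antiproliferative activity, with a stated time of 72 h; on this read-out higher numbers stand for an effect only at larger amounts of compound and lower numbers for an effect already at smaller amounts. Compound 1, with the structure `COC(=O)c1ccc(N(Cc2cnc(C3CCCCC3)cn2)C(=O)[C@H]2CCN2S(=O)(=O)c2c(F)c(F)c(F)c(F)c2F)c(F)c1`, gives 1400 nM in this assay. Compound 2, with the structure `CNC(=O)c1ccc(N(Cc2ccc(C3CCCCC3)cn2)C(=O)[C@H]2CCN2S(=O)(=O)c2c(F)c(F)c(F)c(F)c2F)c(F)c1`, shares the same sulfonyl-bearing core but carries a different aromatic group on the amide-type nitrogen and a different placement of the ring nitrogen in the cyclohexyl-bearing heteroaryl; for compound 2 the entry in this assay reads "not determined" (no result reported), so no number stands for it and nothing can be said about where it sits relative to compound 1.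

Compound 3, with the structure `O=C1NC(=O)c2cc(N(Cc3ccc(C4CCCCC4)cn3)C(=O)[C@H]3CCN3S(=O)(=O)c3c(F)c(F)c(F)c(F)c3F)ccc21`, is the compound still to be measured. It differs from compound 2 in one place: a group of 11 heavy atoms (8 carbon, 1 nitrogen, 2 oxygen; one five-membered non-aromatic ring with 1 hetero atom, one six-membered aromatic ring of carbon only) in place of a group of 11 heavy atoms (8 carbon, 1 nitrogen, 1 oxygen, 1 fluorine; one six-membered aromatic ring of carbon only), on an amide-type nitrogen. Compound 2 has no number. Within the data shown here, no step between measured compounds is available to anchor the size of this change. The expectation is therefore loose: the only measured anchor is the result of compound 1 in this assay, and the shift brought by this change could go in either direction, quite possibly not beyond the usual scatter. On that basis compound 3 is estimated at 1500 nM in this assay, within a range from 300 nM to 8000 nM.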

Compound 3, half-maximal effective concentration: 1700 nM
For compound 3 the middle estimate is 1.1-fold (0.05 log units) below the measured one, and the stated range covers the measured number.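

Compound 3 gives 1700 nM in this assay but compound 2 has no number there, so no step can be read between compound 2 and compound 3. Going by these compounds, the effect of replacing the 2-fluoro-4-(methylcarbamoyl)phenyl group with the group in compound 3 stays open. No further data here bear on this result.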